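A few compounds are considered here, and "the series" means these few. Any claim that something is new, unique, unknown or untested is made for them only; others in the source may bear on it.

Compound 1 `Cc1cccc(NC(=O)[C@@H]2CCCN2S(=O)(=O)c2cccc3cccnc23)c1`: 25500 nM
Compound 2 `CCc1ccccc1NC(=O)[C@@H]1CCCN1S(=O)(=O)c1cccc2cccnc12`: > 50000 nM

In an ADME assay on HEp-2 cells (Homo sapiens) for cytotoxicity (a lower number here means that less compound is tolerated, a higher number that more compound is tolerated), compound 2 gives > 50000 nM, which is a limit of the assay and not a number. This is the sole such case so far: the limit of > 50000 nM in this assay, at which 1 of the 2 values shown sits.

Compound 3 `Cc1ccnc(C)c1NC(=O)[C@@H]1CCCN1S(=O)(=O)c1cccc2cccnc12` carries 2,4-dimethylpyridin-3-yl in place of 2-ethylphenyl on an amide-type nitrogen. Among the measured compounds shown here, one measured step bears on this change, at the same nitrogen: an at least 1.9-fold higher number from compound 1 to compound 2 (0.29 log units; that floor lies within the scatter). That step swaps one carbon-only ring for another, so it offers only loose guidance for a ring with a hetero atom. No step beyond the scatter is therefore expected in this assay, in either direction. The expected step is a number no higher from compound 2 to compound 3 (the limit leaves the size open). The estimate for compound 3 is 50000 nM, with an expected range of 25000 nM to 100000 nM.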

Compound 3, half-maximal cytotoxic concentration: > 50000 nM
Compound 3 was reported as a limit (the forecaster's own chance of this, stated with the estimate: 60%); the middle value sits exactly at the limit.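

Among the compounds shown here, with compound 3, a ring with a hetero atom, 2,4-dimethylpyridin-3-yl, stands on the amide-type nitrogen for the first time, and in this assay compound 3 gives > 50000 nM, which is a limit of the assay and not a number. Set against 3-methylphenyl at the same nitrogen, this group gives an at least 1.9-fold higher number from compound 1 to compound 3 (0.29 log units; that floor lies within the scatter), so this comparison on its own shows no firm rise. The step from compound 2 to compound 3 cannot be read, and the same limit now recurs at this position: the limit of > 50000 nM in this assay, at which 2 of the 3 values shown sit.

Going by these compounds, how far compound 2 and compound 3 lie beyond the limit stays open. Also open, on these data alone, is whether a carboxylic acid or a primary amine on this ring would bring the number down to a readable value.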